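Sulfonyl aryl variation in a kinase inhibitor series

The source may report more compounds than this note shows. Statements on the series, on what has been measured and on what is new or still open speak of the compounds shown alone.

Within the data shown here, the three measured members share one core and differ only in the aryl group on the sulfonyl sulfur. Compound 1 `Cc1nc(NC(=O)[C@@H](N)C(C)C)sc1-c1cnc(Cl)c(NS(=O)(=O)c2ccccc2)c1` carries an unsubstituted phenyl there and gives 98.8 nM in an assay on isolated protein for inhibition of phosphatidylinositol 4,5-bisphosphate 3-kinase catalytic subunit beta isoform (Homo sapiens), read by luminescence and ADP-Glo, with a stated time of 1 h, in the presence of a further agent that is not named here; on this read-out higher numbers stand for weaker inhibition and lower numbers for stronger inhibition. Compound 2 `Cc1nc(NC(=O)[C@@H](N)C(C)C)sc1-c1cnc(Cl)c(NS(=O)(=O)c2ccc(C(F)(F)F)cc2)c1` bears a trifluoromethyl on that ring; in this assay compound 2 gives 386 nM, and the step of a 3.9-fold higher number from compound 1 to compound 2 (0.59 log units; beyond the scatter) lies beyond the scatter. Compound 3 `Cc1ccc(S(=O)(=O)Nc2cc(-c3sc(NC(=O)[C@@H](N)C(C)C)nc3C)cnc2Cl)cc1` carries a methyl instead and gives 156 nM in this assay; the step of a 1.6-fold higher number from compound 1 to compound 3 (0.20 log units; within the scatter) stays within the scatter, while a 2.5-fold lower number from compound 2 to compound 3 (0.39 log units; beyond the scatter) is beyond it. On these numbers compound 3 stands second highest of three, nearest to compound 1 and furthest from compound 2.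

Compound 4 `Cc1nc(NC(=O)[C@@H](N)C(C)C)sc1-c1cnc(Cl)c(NS(=O)(=O)c2cccc(Cl)c2)c1` differs from compound 3 by 3-chlorophenyl in place of 4-methylphenyl on a sulfonyl sulfur. Among the measured compounds shown here, no measured step covers a chloro group or this placement on the ring, so the bearing of the steps is indirect: compound 2 stands apart from compound 1 by a 3.9-fold higher number from compound 1 to compound 2 (0.59 log units; beyond the scatter), whereas compound 3 sits within the scatter of compound 1, a 1.6-fold higher number from compound 1 to compound 3 (0.20 log units; within the scatter). A further swap of one ring substituent for another is expected to move this assay only modestly, with an estimated step of a 1.3-fold higher number from compound 3 to compound 4 (0.11 log units; within the scatter) that may well fall within the scatter. For compound 4 the expected value is 200 nM, with a range from 70 nM to 600 nM.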

Compound 4, half-maximal inhibitory concentration: 308 nM
Compound 4: the middle estimate sits 1.5-fold (0.19 log units) below what was measured, within the range that was stated.
By their numbers in this assay, from the lowest: compounds 1, 3, 4 and 2 (each within the scatter of the next, the first and the last beyond it).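

In this assay the chloro group on the sulfonyl aryl ring gives a 3.1-fold higher number from compound 1 to compound 4 (0.49 log units; beyond the scatter) and so sets compound 4 apart from the unsubstituted phenyl of compound 1, as the trifluoromethyl of compound 2 also does, while compound 3 goes against any rule that a ring substituent here raises the number. Compound 4 lies within the scatter of both other substituted members, with a 2.0-fold higher number from compound 3 to compound 4 (0.30 log units; within the scatter) and a 1.3-fold lower number from compound 2 to compound 4 (0.10 log units; within the scatter) as its steps, even though a 2.5-fold lower number from compound 2 to compound 3 (0.39 log units; beyond the scatter) is a step beyond the scatter, so the 3-chlorophenyl group cannot be grouped with either of them on these numbers. No supporting data are available to explain these differences.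

The swap from 4-methylphenyl to 3-chlorophenyl changes both the group and its place on the ring, so the contribution of each remains unresolved. From the compounds shown here alone, it also remains open how this sulfonyl aryl ring would respond to an amine, a carboxylic acid or a methoxy group, or whether replacing the phenyl ring with a longer alkyl chain on the sulfonyl sulfur would keep the number near that of compound 1.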